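The source may report more compounds than this note shows. Statements on the series, on what has been measured and on what is new or still open speak of the compounds shown alone.

Among the compounds with values here, compound 3 `COc1ccc(CN2C(=O)C(=O)c3cc(-c4ccc(OC)cc4)ccc32)cc1` gives 30 nM in a functional assay on K562 cells (Homo sapiens) for antiproliferative activity, read by MTT assay, with a stated time of 48 h (on this read-out lower numbers stand for stronger inhibition and higher numbers for weaker inhibition), the lowest of the three numbers known here. Compound 1 `COc1ccc(-c2ccc3c(c2)C(=O)C(=O)N3Cc2ccc(F)cc2)cc1` gives 560 nM and compound 2 `COc1ccc(-c2ccc3c(c2)C(=O)C(=O)N3Cc2ccc(Cl)c(Cl)c2)cc1` gives 430 nM in this assay. Compound 4 `COc1ccc(-c2ccc3c(c2)C(=O)C(=O)N3Cc2ccc3ccccc3c2)cc1` differs from compound 3 in one place: naphthalen-2-yl in place of 4-methoxyphenyl on a saturated chain carbon bound to an amide-type nitrogen in a ring. Two earlier steps bear on this position. Within the data shown here, the number fell a 19-fold lower number from compound 1 to compound 3 (1.27 log units; beyond the scatter) and a 14-fold lower number from compound 2 to compound 3 (1.16 log units; beyond the scatter), so the methoxy-bearing ring on this carbon goes with the lowest number, while no measured compound carries a group without an acceptor there. Taking naphthalen-2-yl as closer to the halogenated rings than to 4-methoxyphenyl, a clearly higher number is expected for compound 4, about a 5.0-fold higher number from compound 3 to compound 4 (0.70 log units; beyond the scatter). The estimate for compound 4 is 150 nM, with a range from 40 nM to 600 nM.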

Compound 4, half-maximal inhibitory concentration: 400 nM
Compound 4: the middle estimate sits 2.7-fold (0.43 log units) below what was measured; the range from low to high includes it.
By their numbers in this assay, from the lowest: compound 3; then compounds 4, 2 and 1 (each within the scatter of the next).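

In this assay, naphthalen-2-yl, with two aromatic rings and no hydrogen-bond acceptor, gives a 13-fold higher number from compound 3 to compound 4 (1.12 log units; beyond the scatter) when it takes the place of 4-methoxyphenyl. Against the halogenated rings, the same group gives a 1.1-fold lower number from compound 2 to compound 4 (0.03 log units; within the scatter) and a 1.4-fold lower number from compound 1 to compound 4 (0.15 log units; within the scatter), so compounds 1, 2 and 4 sit level despite their different groups on this carbon, and only compound 3 stands apart. No measured evidence explains this pattern. An unsubstituted phenyl or an aminophenyl ring on this carbon would help show whether the methoxy group itself sets compound 3 apart.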